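This account rests on a few compounds, and the source may have more. Where it says the series, first, only, none or still open, it means among the compounds named here.

In an ADME assay on cells (Hepatocyte, Mus musculus) for cytotoxicity, read by MTT assay, with a stated time of 24 h (a higher number here means that more compound is tolerated, a lower number that less compound is tolerated), compound 1 `FC(F)(F)c1ccc(-c2nn(-c3ccccc3)cc2-c2nc3ccccc3[nH]2)cc1` gives 159000 nM and compound 2 `O=[N+]([O-])c1ccc(S(=O)(=O)n2c(-c3cn(-c4ccccc4)nc3-c3ccc(C(F)(F)F)cc3)nc3ccccc32)cc1` gives 178000 nM. Among the compounds with values here, compound 2 therefore stands level with compound 1, the only other measured member of the series, and the two cannot be separated within the scatter. Compound 3 `O=S(=O)(c1ccc(Br)cc1)n1c(-c2cn(-c3ccccc3)nc2-c2ccc(C(F)(F)F)cc2)nc2ccccc21` keeps the sulfonyl group of compound 2 and carries one change: bromo in place of nitro on an aromatic carbon. This places bromo in place of nitro on an aromatic carbon, para to a large group. Within the data shown here, no measured step covers this exchange directly. The nearest evidence is a 1.1-fold higher number from compound 1 to compound 2 (0.05 log units; within the scatter), where adding the complete (4-nitrophenyl)sulfonyl group left the number within the scatter. On that single step, no shift beyond the scatter is expected in this assay. The expected change is a 1.0-fold lower number from compound 2 to compound 3 (0.02 log units; within the scatter). For compound 3 the estimated value is 170000 nM, with an expected range of 90000 nM to 320000 nM.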

Compound 3, half-maximal cytotoxic concentration: 167000 nM
Compound 3: the middle estimate sits 1.0-fold (0.01 log units) above what was measured, within the range that was stated.
By their numbers in this assay, from the lowest: compounds 1, 3 and 2 (each within the scatter of the next).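

In this assay, bromo in place of nitro on an aromatic carbon, para to a large group, gives a 1.1-fold lower number from compound 2 to compound 3 (0.03 log units; within the scatter) and is the first change shown on the phenyl ring of the sulfonyl group rather than on the aromatic nitrogen. The complete (4-bromophenyl)sulfonyl group in place of hydrogen on that nitrogen gives a 1.1-fold higher number from compound 1 to compound 3 (0.02 log units; within the scatter) and so joins (4-nitrophenyl)sulfonyl as a second such group that cannot be separated from hydrogen here. Nothing measured on these compounds accounts for the absence of a shift beyond the scatter.

Going by these compounds, whether an amine or a carboxylic acid at this place on the phenyl ring would give a step beyond the scatter stays open. The same holds for a longer alkyl chain on the sulfonyl group in place of the whole 4-bromophenyl group.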